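Replacing 4,4-difluorocyclohexyl on a sulfonyl sulfur

The compounds below may be only part of what the source reports. "The series", "measured", "known", "first", "only" and "open" are said of these compounds alone.

Compound 1 `O=C(NCc1ccc(S(=O)(=O)c2ccccc2)cc1)N1Cc2ccncc2C1`: 115000 nM
Compound 2 `O=C(NCc1ccc(S(=O)(=O)C2CCC(F)(F)CC2)cc1)N1Cc2ccncc2C1`: 35000 nM

In a physicochemical assay for solubility, in phosphate buffer, with a stated time of 24 h, at pH 7.4, tested at 100 uM (on this read-out lower numbers stand for lower solubility and higher numbers for higher solubility), compound 2, at 35000 nM, holds the lower of the two numbers. Compound 3 `CN1CCC(S(=O)(=O)c2ccc(CNC(=O)N3Cc4ccncc4C3)cc2)CC1` keeps the shared core and differs from compound 2 in one group: 1-methylpiperidin-4-yl in place of 4,4-difluorocyclohexyl on a sulfonyl sulfur. Among the measured compounds shown here, one measured step bears on this place, a 3.3-fold lower number from compound 1 to compound 2 (0.52 log units; beyond the scatter), a modest step made when 4,4-difluorocyclohexyl came in place of phenyl. For the measured compounds named here, no measured compound carries 1-methylpiperidin-4-yl, so the reading is tentative. A step of similar size, upward, is expected in this assay: a 2.6-fold higher number from compound 2 to compound 3 (0.41 log units; beyond the scatter). For compound 3 the estimated value is 90000 nM, with an expected range of 45000 nM to 150000 nM.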

Compound 3, solubility: 240000 nM
Compound 3: the middle estimate sits 2.7-fold (0.43 log units) below what was measured, and the stated range ends below it.
By their numbers in this assay, from the lowest: compound 2; then compound 1; then compound 3.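

In this assay, this place on the sulfonyl sulfur moves the number in both directions relative to phenyl: 1-methylpiperidin-4-yl gives a 6.9-fold higher number from compound 2 to compound 3 (0.84 log units; beyond the scatter) and a 2.1-fold higher number from compound 1 to compound 3 (0.32 log units; beyond the scatter). A six-membered non-aromatic ring alone therefore does not fix the outcome, since compound 2 and compound 3 both carry one yet hold the lowest and highest numbers of the three. Nothing available gives a cause for this change. The compounds shown leave open whether the ring nitrogen or its methyl group matters more. From the compounds shown here alone, how piperidin-4-yl without the methyl group, or a morpholine ring, would read at this place also remains open.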